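This account rests on a few compounds, and the source may have more. Where it says the series, first, only, none or still open, it means among the compounds named here.

Series notes, aryl versus alkyl on the amide-type nitrogen of the shared core.

Compound 1 `CC(=O)Oc1ccc(N2C(=O)/C(=C/N3N=C(c4ccccc4)CC3c3ccccc3O)SC2=S)cc1` carries a 4-acetoxyphenyl on that nitrogen; in a functional assay on SK-OV-3 cells (Homo sapiens) for antiproliferative activity, read by MTT assay, with a stated time of 72 h (on this read-out lower numbers stand for stronger inhibition and higher numbers for weaker inhibition), compound 1 gives 244 nM. Compound 2 `CCN1C(=O)/C(=C/N2N=C(c3ccccc3)CC2c2ccccc2O)SC1=S` carries an ethyl there instead. In this assay compound 2 gives > 10000 nM, which is a limit of the assay rather than a number (the limit of > 10000 nM in this assay, at which 1 of the 2 values shown sits). For the measured compounds named here, the one measured step runs an at least 40-fold higher number from compound 1 to compound 2 (1.61 log units; beyond the scatter), so compound 2 stands at the weak end of the two values shown, and only its limit is known.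

Compound 3 `O=C1/C(=C/N2N=C(c3ccccc3)CC2c2ccccc2O)SC(=S)N1c1cccc(C(F)(F)F)c1` is the next member. Relative to compound 2 the change is 3-(trifluoromethyl)phenyl in place of ethyl on an amide-type nitrogen in a ring. It reverses the type of change seen from compound 1 to compound 2, putting a phenyl ring back on the nitrogen, though with a trifluoromethyl in place of the acetoxy and at a different named position. That measured step was large and beyond the scatter, so a large step in the opposite direction is expected here, towards a lower number in this assay. Compound 3 is therefore expected at 600 nM, with a range of 150 nM to 4000 nM, which corresponds to an expected step of an at least 16-fold lower number from compound 2 to compound 3 (1.22 log units; beyond the scatter).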

Compound 3, half-maximal inhibitory concentration: > 10000 nM
Compound 3 gave a limit, no number; the forecaster's own chance of this, stated with the estimate: 15%; middle value at least 16-fold (1.22 log units) away from the limit.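

Replacing 4-acetoxyphenyl with 3-(trifluoromethyl)phenyl on the amide-type nitrogen gives an at least 40-fold higher number from compound 1 to compound 3 (1.61 log units; beyond the scatter), so in this assay a phenyl ring at this position does not by itself secure a measurable value. The step from compound 2 to compound 3 cannot be read: both values are limits, and ethyl and 3-(trifluoromethyl)phenyl cannot be ordered against each other. Of the three groups shown on this nitrogen, only the 4-acetoxyphenyl of compound 1 gives a number, and the other two compounds end at the same limit: the limit of > 10000 nM in this assay, at which 2 of the 3 values shown sit.

Compound 1 and compound 3 differ in both the group on the phenyl ring and its named position, so the data do not separate these two changes; 4-(trifluoromethyl)phenyl and 3-acetoxyphenyl on the same nitrogen would do so. Also open, on these data alone, is what the acetoxy contributes within the 4-substituted phenyl, a question that an unsubstituted phenyl, a 4-hydroxyphenyl or a 4-methoxyphenyl at this position would address.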